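Aryl-to-cyclohexyl swap on the alkenyl chain of the shared core

The source may hold more compounds than are shown below. What is called first, only, known or untested is meant among the compounds shown, and "the series" means these compounds.

Measured so far: compound 1 `COc1cccc(/C=C/C[C@@H]2C[C@@H]([C@@H](O)c3ccc(OC)c(OC)c3)CO[C@H]2c2ccc(OC)c(OC)c2)c1`, 16400 nM; compound 2 `Cc1ccc(/C=C/C[C@H]2C[C@@H]([C@@H](O)c3ccccc3)CO[C@@H]2c2ccccc2)cc1C`, 10000 nM; compound 3 `COc1ccc(/C=C/C[C@@H]2C[C@@H]([C@@H](O)c3ccc(OC)c(OC)c3)CO[C@H]2c2ccc(OC)c(OC)c2)cc1OC`, 30600 nM, all in a functional assay on HeLa cells (Homo sapiens) for cytotoxicity, read by WST assay, with a stated time of 48 h; on this read-out lower numbers stand for stronger inhibition and higher numbers for weaker inhibition.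

Compound 2 sits at the low end of the three numbers; the gap to compound 1 lies within the scatter, while the gap to compound 3 lies beyond it. Going by the values given here, the only single-point step, a 1.9-fold higher number from compound 1 to compound 3 (0.27 log units; within the scatter), concerns a methoxy on an aromatic carbon and stays within the scatter.

Compound 4 `O[C@@H](c1ccccc1)[C@H]1CO[C@H](c2ccccc2)[C@@H](C/C=C/C2CCCCC2)C1` differs from compound 2 by cyclohexyl in place of 3,4-dimethylphenyl on a double-bonded chain carbon bound to a double-bonded chain carbon. Among the compounds with values here, no measured step covers the loss of the aromatic ring, so no step beyond the scatter is assumed in this assay; compound 4 is expected near compound 2, at 12000 nM, within 4000 nM to 36000 nM, an estimated step of a 1.2-fold higher number from compound 2 to compound 4 (0.08 log units; within the scatter).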

Compound 4, half-maximal inhibitory concentration: 6440 nM
For compound 4 the middle estimate is 1.9-fold (0.27 log units) above the measured one; the measured number falls inside the stated range.
By their numbers in this assay, from the lowest: compounds 4, 2, 1 and 3 (each within the scatter of the next, the first and the last beyond it).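

In this assay, cyclohexyl in place of 3,4-dimethylphenyl gives a 1.6-fold lower number from compound 2 to compound 4 (0.19 log units; within the scatter). Going by these compounds alone, at this place on the chain, the pair therefore shows that a non-aromatic ring can stand in for the aromatic one without a change beyond the scatter, which the methoxy step between the earlier compounds could not show. No evidence on this pair is available to explain the result.

As far as these compounds go, whether the same swap holds on the methoxy-bearing core of compound 1 stays open. So does the outcome with an amine, a carboxylic acid or a longer chain at this place.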